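Compound 4 and its 1H-indol-2-yl group

This account rests on a few compounds, and the source may have more. Where it says the series, first, only, none or still open, it means among the compounds named here.

In an ADME assay (liver) for metabolic stability, with Liver microsome (Rattus norvegicus) as the target, using microsomes and NADPH, with a stated time of 30 min, tested at 1 uM (on this read-out lower numbers stand for slow clearance and higher numbers for fast clearance), compound 1 `COCC#Cc1cc(C(O)(C(F)(F)F)C(F)(F)F)cnc1N1CCN(S(=O)(=O)c2ccc(N)nc2)CC1` gives 399 mL.min-1.g-1, compound 2 `Cc1nc2cc(-c3cc(C(O)(C(F)(F)F)C(F)(F)F)cnc3N3CCN(S(=O)(=O)c4ccc(N)nc4)CC3)ccc2o1` gives 99 mL.min-1.g-1 and compound 3 `Nc1ccc(S(=O)(=O)N2CCN(c3ncc(C(O)(C(F)(F)F)C(F)(F)F)cc3-c3ccc4c(c3)CC(=O)N4)CC2)cn1` gives 119 mL.min-1.g-1. Compound 3 thus stands level with compound 2 and clearly under compound 1. Compound 4 `Nc1ccc(S(=O)(=O)N2CCN(c3ncc(C(O)(C(F)(F)F)C(F)(F)F)cc3-c3cc4ccccc4[nH]3)CC2)cn1` differs from compound 3 at one aromatic carbon, meta to a 2,2,2-trifluoro-1-hydroxy-1-(trifluoromethyl)ethyl group, where 1H-indol-2-yl enters: a group of 9 heavy atoms (8 carbon, 1 nitrogen; one five-membered aromatic ring with 1 hetero atom, one six-membered aromatic ring of carbon only) in place of a group of 10 heavy atoms (8 carbon, 1 nitrogen, 1 oxygen; one five-membered non-aromatic ring with 1 hetero atom, one six-membered aromatic ring of carbon only), on an aromatic carbon.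

Two measured steps replace the open 3-methoxyprop-1-yn-1-yl chain with a two-ring group, and both lower the number: a 4.0-fold lower number from compound 1 to compound 2 (0.61 log units; beyond the scatter) and a 3.4-fold lower number from compound 1 to compound 3 (0.53 log units; beyond the scatter). For the measured compounds named here, the closest precedent is the only exchange of one two-ring group for another, a 1.2-fold higher number from compound 2 to compound 3 (0.08 log units; within the scatter), which stays within the scatter. On that precedent, no step beyond the scatter is expected in this assay. Going by the values given here, no measured compound carries 1H-indol-2-yl, so the range is kept wide. The expected change is a 1.2-fold higher number from compound 3 to compound 4 (0.07 log units; within the scatter). For compound 4 the estimate is 140 mL.min-1.g-1, with an expected range of 65 mL.min-1.g-1 to 300 mL.min-1.g-1.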

Compound 4, intrinsic clearance in microsomes: 146 mL.min-1.g-1
Compound 4: middle estimate off by 1.0-fold (0.02 log units), on the low side, within the range that was stated.
By their numbers in this assay, from the lowest: compounds 2, 3 and 4 (each within the scatter of the next); then compound 1.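

In this assay, 1H-indol-2-yl brings a five-membered aromatic ring where compound 3 has a five-membered non-aromatic ring, yet a 1.2-fold higher number from compound 3 to compound 4 (0.09 log units; within the scatter) and a 1.5-fold higher number from compound 2 to compound 4 (0.17 log units; within the scatter) both stay within the scatter, so this position now tolerates three different two-ring groups with no step beyond it. Against the open 3-methoxyprop-1-yn-1-yl chain, the step is a 2.7-fold lower number from compound 1 to compound 4 (0.44 log units; beyond the scatter), which places all three two-ring groups on the same side of compound 1, with no compound shown going against that. Nothing available here explains why the numbers fall this way.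

From the compounds shown here alone, whether a single ring such as phenyl would side with the two-ring groups or with compound 1 remains open. So does the effect on this read-out of a chain ending in an amine or a carboxylic acid on this aromatic carbon.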